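Methyl for methoxy on two cores: cytotoxicity notes

The source may hold more compounds than are shown below. What is called first, only, known or untested is meant among the compounds shown, and "the series" means these compounds.

Compound 1 `COc1cc(Nc2ccnc(Nc3ccc(C#N)cc3)n2)ccc1-c1ccc(C#N)cc1` and compound 3 `Cc1cc(Nc2ccnc(Nc3ccc(C#N)cc3)n2)ccc1-c1ccc(C#N)cc1` share one core; compound 2 `COc1cc(-c2ccc(C#N)cc2)ccc1Nc1ccnc(Nc2ccc(C#N)cc2)n1` and the unmeasured compound 4 `Cc1cc(-c2ccc(C#N)cc2)ccc1Nc1ccnc(Nc2ccc(C#N)cc2)n1` share another, and the difference between the two cores is not broken down here. In a functional assay on MT4 cells (Homo sapiens) for cytotoxicity, read by MTT assay, with a stated time of 5 days (a higher number here means that more compound is tolerated, a lower number that less compound is tolerated), compound 1 gives 5260 nM and compound 3 gives 12400 nM. The step of a 2.4-fold higher number from compound 1 to compound 3 (0.37 log units; beyond the scatter) goes with the change (methyl in place of methoxy on an aromatic carbon). Compound 2 is reported only as a limit, > 298000 nM, which is the limit of > 298000 nM in this assay, at which 1 of the 3 values shown sits. Compound 4 arises by methyl in place of methoxy on an aromatic carbon; the place is ortho to a large group and meta to the 4-cyanophenyl group, where before it was ortho to the 4-cyanophenyl group and meta to a large group, so this is the same kind of change. Compound 4 is expected at 300000 nM, between 100000 nM and 700000 nM. The expected step is a step that the limit leaves unreadable from compound 2 to compound 4, placed beside a 2.4-fold higher number from compound 1 to compound 3 (0.37 log units; beyond the scatter), and compound 4 is expected most likely to return only a limit again.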

Compound 4, half-maximal cytotoxic concentration: 9200 nM
The estimate for compound 4 lay 33-fold (1.51 log units) above the measured number, outside the stated range (below it).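

On the core of compound 2, methyl in place of methoxy gives an at least 32-fold lower number from compound 2 to compound 4 (1.51 log units; beyond the scatter), and this size is only a minimum. In this assay compound 2 is reported only as a limit, > 298000 nM. The two pairs show that neither the size nor the direction of this change carries from one core to the other, but they give neither a reason for the gap nor a rule for any further core: the same change on two cores in this assay, a 2.4-fold higher number (0.37 log units; beyond the scatter) from compound 1 to compound 3 and an at least 32-fold lower number (1.51 log units; beyond the scatter) from compound 2 to compound 4, at least 76-fold (1.88 log units) apart, beyond the scatter of two such steps

On these data alone, it remains open how an ethoxy group, a fluorine or an amine in place of the methoxy would behave on either core. As far as these compounds go, it also remains open whether such groups would separate the two cores in the same way.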